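Sugar-linked triazole series: cytotoxicity on Vero cells

A few compounds are considered here, and "the series" means these few. Any claim that something is new, unique, unknown or untested is made for them only; others in the source may bear on it.

Compound 3 `CC(=O)C[C@H]1O[C@@H](On2cc(CN3C(=O)/C(=N\Nc4ccc(Br)cc4)c4ccccc43)nn2)[C@H](OC(C)=O)[C@@H](OC(C)=O)[C@H]1OC(C)=O` stands second highest of the three numbers in an ADME assay on Vero cells (Chlorocebus sabaeus) for cytotoxicity, read by fluorescence and resazurin assay, with a stated time of 3 days (on this read-out higher numbers stand for lower toxicity in this test and lower numbers for higher toxicity in this test), where compound 3 gives 83400 nM. Compound 1 `COc1ccc(N/N=C2\C(=O)N(Cc3cn(O[C@@H]4O[C@H](CC(C)=O)[C@@H](OC(C)=O)[C@H](OC(C)=O)[C@H]4OC(C)=O)nn3)c3ccccc32)cc1` gives 95300 nM and compound 2 `CC(=O)C[C@H]1O[C@@H](On2cc(CN3C(=O)/C(=N\Nc4ccccc4)c4ccccc43)nn2)[C@H](OC(C)=O)[C@@H](OC(C)=O)[C@H]1OC(C)=O` gives 65200 nM; all three lie within the scatter of one another. Compound 4 `COc1ccc(N/N=C2\C(=O)N(Cc3cn(O[C@@H]4O[C@H](CC(C)=O)[C@H](OC(C)=O)[C@H](OC(C)=O)[C@H]4OC(C)=O)nn3)c3ccccc32)cc1` differs from compound 3 by methoxy in place of bromo on an aromatic carbon. Among the compounds with values here, the one step that bears on a change on this aromatic carbon, a 1.3-fold higher number from compound 2 to compound 3 (0.11 log units; within the scatter), did not leave the scatter, and compound 1, which also carries the methoxy group, sits at 95300 nM. No step beyond the scatter is therefore expected in this assay. Compound 4 is estimated at 88000 nM, range 45000 nM to 170000 nM, meaning an expected step of a 1.1-fold higher number from compound 3 to compound 4 (0.02 log units; within the scatter).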

Compound 4, half-maximal cytotoxic concentration: 62500 nM
Beside the measured number, compound 4's estimate is 1.4-fold (0.15 log units) above it, within the range that was stated.
By their numbers in this assay, from the lowest: compounds 4, 2, 3 and 1 (each within the scatter of the next).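

In this assay, methoxy on this aromatic carbon, para to a large group, stays within the scatter both against bromo (a 1.3-fold lower number from compound 3 to compound 4 (0.13 log units; within the scatter)) and against hydrogen (a 1.0-fold lower number from compound 2 to compound 4 (0.02 log units; within the scatter)). The series also gains its first reading on drawn configuration, at a saturated ring carbon, and that step stays within the scatter too (a 1.5-fold lower number from compound 1 to compound 4 (0.18 log units; within the scatter)). This comparison isolates configuration: the fact that compounds 1 and 4 differ only in the configuration as drawn

Going by these compounds, whether an amine or a carboxylic acid on this aromatic carbon would leave the scatter remains open. So does the reading at the other stereocentres.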